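Dropping a Chloro from a Tightly Bound Acid

The source may hold more compounds than are shown below. What is called first, only, known or untested is meant among the compounds shown, and "the series" means these compounds.

In an ADME assay on the whole organism (plasma, Rattus norvegicus, strain Han-Wistar) for protein binding, read by LC-MS, at a dose of 1 mg/kg by the intravenous route, compound 1 `C[C@@H](Oc1cc2onc(CCC(=O)O)c2cc1Cl)c1ccc(Cl)cn1` gives 99.7%, the lower of the two unbound fractions measured so far, while compound 2 `O=C(O)CCn1c(=O)oc2cc(OCC3CC3)c(Cl)cc21` gives 90.2%, a markedly larger unbound fraction and a gap beyond the usual scatter. Compound 3 `C[C@@H](Oc1cc2onc(CCC(=O)O)c2cc1Cl)c1ccccn1` has not yet been measured; it differs from compound 1 only by hydrogen in place of chloro on an aromatic carbon. Going by the values given here, no step between measured compounds matches this change, so its size can only be estimated: a small move toward a larger unbound fraction, at most slightly beyond the scatter, is expected, as a 2.3-fold higher unbound fraction from compound 1 to compound 3 (0.37 log units; beyond the scatter). For compound 3 the estimate is 99.3%, within 98.5% to 99.8%.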

Compound 3, plasma protein binding in the plasma assay: 97.8%
For compound 3 the middle estimate is 3.1-fold (0.50 log units) (unbound fraction) below the measured one; the measured number lies below the stated range.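

In the plasma assay, going from 5-chloropyridin-2-yl to pyridin-2-yl gives a 7.3-fold higher unbound fraction from compound 1 to compound 3 (0.87 log units; beyond the scatter), showing that this single chloro, para to a large group, has a measurable hold on how much compound stays free. In a physicochemical assay for pharmacokinetics, at pH 6 (a higher number here means that the compound lasts longer, a lower number that the compound disappears faster), compound 1 gives > 1000 h, which is a limit of the assay. In the physicochemical assay, compound 3 gives > 1000 h, also a limit, so no step between the two can be read: the limit of > 1000 h in the physicochemical assay, at which 2 of the 2 values shown sit.

As far as these compounds go, whether a fluoro, a methyl or a methoxy at this place would free as much compound remains open. So does whether the same change would have a similar effect on another core.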